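Amine substituent change on the shared core: compounds 2 to 3

The compounds below may be only part of what the source reports. "The series", "measured", "known", "first", "only" and "open" are said of these compounds alone.

Compound 1 `CCCCN1CCc2nc(C#Cc3ccccc3)sc2C1` and compound 2 `COC1CC(C(=O)N2CCc3nc(C#Cc4ccccc4)sc3C2)C1` share one core and differ only at the amine nitrogen in a ring. In an assay on HEK293 cells for negative allosteric modulation of metabotropic glutamate receptor 5 (Homo sapiens), read by FLIPR, with a stated time of 1 h (on this read-out higher numbers stand for weaker inhibition and lower numbers for stronger inhibition), compound 1 gives > 10000 nM, which is a limit of the assay. In this assay compound 2 likewise gives > 10000 nM, a limit and not a number. The step that the two limits leave unreadable from compound 1 to compound 2 therefore cannot be read, and the limit of > 10000 nM in this assay, at which 2 of the 2 values shown sit, is all these two values show. Compound 3 `O=S(=O)(C1CC1)N1CCc2nc(C#Cc3ccccc3)sc2C1` is not yet measured; it differs from compound 2 by cyclopropylsulfonyl in place of (3-methoxycyclobutyl)carbonyl on an amine nitrogen in a ring. Among the compounds with values here, no measured step bears on this change, since the only step in hand is unreadable. For compound 3 the expected step that the limit leaves unreadable from compound 2 to compound 3 is one without a readable direction beyond the scatter. For compound 3 in this assay the estimate is 15000 nM, with a range from 3000 nM to 60000 nM.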

Compound 3, half-maximal inhibitory concentration: 34 nM
Compound 3: the middle estimate sits 440-fold (2.64 log units) above what was measured; the whole stated range lies above it.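

In this assay, the group on the amine nitrogen in a ring proves able to move the read-out, which the earlier pair could not show, as the step between compound 1 and compound 2 cannot be read. Cyclopropylsulfonyl in place of (3-methoxycyclobutyl)carbonyl gives an at least 290-fold lower number from compound 2 to compound 3 (2.46 log units; beyond the scatter) and cyclopropylsulfonyl in place of butyl gives an at least 290-fold lower number from compound 1 to compound 3 (2.46 log units; beyond the scatter). On these data alone, both steps start from a limit and not a number, so their true sizes stay unknown: the limit of > 10000 nM in this assay, at which 2 of the 3 values shown sit.

As far as these compounds go, the sulfonyl link and the cyclopropyl ring enter together, so it remains open which of them carries the change; cyclopropylcarbonyl or methylsulfonyl on the same nitrogen would separate the two. Also open, from the compounds shown here alone, is how a phenylsulfonyl group or a longer alkylsulfonyl chain would read at this place.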